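Trading a tetrazole chain for a carboxyethyl chain

A few compounds are considered here, and "the series" means these few. Any claim that something is new, unique, unknown or untested is made for them only; others in the source may bear on it.

Measured so far:
compound 1, `CC(CCc1ccc(OCc2ccc3ccccc3n2)cc1)Cc1nnn[nH]1`: 25 nM
compound 2, `CC(CCC(=O)O)Cc1cccc(OCc2ccc3ccccc3n2)c1`: 140 nM

In an assay on membranes from lung (Cavia porcellus) for binding affinity to cysteinyl leukotriene receptor (Homo sapiens) (on this read-out lower numbers stand for stronger inhibition and higher numbers for weaker inhibition), compound 1 gives 25 nM, the lowest of the two numbers shown; compound 2 gives 140 nM, a gap that lies beyond the usual scatter. Compound 3, `CCCC(CCC(=O)O)Cc1ccc(OCc2ccc3ccccc3n2)cc1`, is not yet measured. It differs from compound 1 in one place: 1-(2-carboxyethyl)butyl in place of 2-((1H-tetrazol-5-yl)methyl)propyl on a saturated chain carbon bound to an aromatic carbon. Compound 2 carries a carboxylic acid at the end of its chain as well, though on a differently substituted core, so it is only a rough guide. The expectation is that the step from compound 1 to compound 3 weakens binding by a 3.2-fold higher number from compound 1 to compound 3 (0.51 log units; beyond the scatter), because compound 2 with its acid chain gives 140 nM. Compound 3 is therefore estimated at 80 nM, with a range from 25 nM to 300 nM.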

Compound 3, inhibition constant: 21 nM
Estimate against measurement, compound 3: 3.8-fold (0.58 log units) above; measured number outside the range, below it.
By their numbers in this assay, from the lowest: compounds 3 and 1 (each within the scatter of the next); then compound 2.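

In this assay, putting 1-(2-carboxyethyl)butyl in place of 2-((1H-tetrazol-5-yl)methyl)propyl on a saturated chain carbon bound to an aromatic carbon gives a 1.2-fold lower number from compound 1 to compound 3 (0.08 log units; within the scatter). So on this core, a group with no ring that carries a carboxylic acid reads the same as the group holding the five-membered aromatic ring, and the tetrazole ring is not needed for binding at this level. Nothing measured here explains why the two groups read alike.

The step replaces the whole group at once, so the compounds shown cannot separate what the carboxylic acid contributes from what the rest of the butyl chain contributes. Also open, as far as these compounds go, is how a primary amide, a sulfonic acid or an amine would read in that same place.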